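The source may hold more compounds than are shown below. What is called first, only, known or untested is meant among the compounds shown, and "the series" means these compounds.

Measured compounds:
Compound 1, `CCCN(CCC)c1c(Cl)cc(Cl)c2nc(Nc3c(C)cc(Cl)cc3OC)n(C)c12`: 170 nM
Compound 2, `CCN(CC)c1ccc(OC)c2nc(Nc3c(C)cc(Cl)cc3OC)n(C)c12`: 13 nM

In an assay on CHO cells for displacement of a labelled ligand from corticotropin-releasing factor receptor 1 (Homo sapiens), read by scintillation counting, with a stated time of 1.5 h (on this read-out higher numbers stand for weaker inhibition and lower numbers for stronger inhibition), compound 2 gives 13 nM, the lower of the two numbers, while compound 1 gives 170 nM, a gap beyond the usual scatter. Compound 3, `CCN(CC)c1ccc(C)c2nc(Nc3c(C)cc(Cl)cc3OC)n(C)c12`, has not been measured; it differs from compound 2 by methyl in place of methoxy on an aromatic carbon. Among the measured compounds shown here, no measured pair shows this change, so no step in this assay can be read off from the data. The change is expected to raise the number only modestly, close to the edge of the scatter, a 1.7-fold higher number from compound 2 to compound 3 (0.23 log units; within the scatter). Compound 3 is therefore estimated at 22 nM, between 7 nM and 65 nM.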

Compound 3, half-maximal inhibitory concentration: 7.6 nM
Compound 3: the middle estimate sits 2.9-fold (0.46 log units) above what was measured; the range from low to high includes it.
By their numbers in this assay, from the lowest: compounds 3 and 2 (each within the scatter of the next); then compound 1.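

In this assay, the change of methoxy to methyl para to a diethylamino group gives a 1.7-fold lower number from compound 2 to compound 3 (0.23 log units; within the scatter) and so shows that this position can lose the methoxy group, with its hydrogen-bond acceptor, without a change beyond the scatter. Compound 1 differs from both in more than one place and could not show this. Nothing at hand offers an explanation for this result.

Still open, on these data alone, is how an ethyl group, a primary amine or a carboxylic acid would fare at this position. As far as these compounds go, whether the same change would give a similar step on another core also remains open.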